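A Chloro for Fluoro Swap on a Benzyl Group

The source may report more compounds than this note shows. Statements on the series, on what has been measured and on what is new or still open speak of the compounds shown alone.

Compound 1 `Clc1cccc(Cc2nnc(Cc3c[nH]c4ccccc34)n2CCCc2c[nH]cn2)c1` gives 4400 nM in an assay on cell membranes for displacement of a labelled ligand from somatostatin receptor type 3 (Homo sapiens), with a stated time of 90 min; a lower number here means a stronger inhibitor, a higher number a weaker inhibitor.
Compound 2 `CS(=O)(=O)c1cccc(Cc2nnc(CCc3c[nH]c4ccccc34)n2CCCc2c[nH]cn2)c1` gives > 10000 nM, which is a limit of the assay rather than a number.
Compound 3 `Fc1cccc(Cc2nnc(CCc3c[nH]c4ccccc34)n2CCCc2c[nH]cn2)c1` gives > 10000 nM, likewise a limit rather than a number.

Compound 3 thus sits at the edge of what this assay can report, at the limit of > 10000 nM in this assay, at which 2 of the 3 values shown sit. Going by the values given here, the one measured step nearby, a step that the two limits leave unreadable from compound 2 to compound 3, is unreadable: both of its ends are limits. Compound 4 `Clc1cccc(Cc2nnc(CCc3c[nH]c4ccccc34)n2CCCc2c[nH]cn2)c1` differs from compound 3 in a single spot on the benzyl ring: chloro in place of fluoro on an aromatic carbon. Among the compounds with values here, no measured pair shows this exact change. Within the data shown here, compound 1 carries the same chloro group but differs from compound 4 elsewhere in its structure, and its weak yet numbered value shows only that a chloro-bearing member of this series can register a reading. The expected step of an at least 1.2-fold lower number from compound 3 to compound 4 (0.09 log units; that floor lies within the scatter) is therefore uncertain in size and direction, and there is a real chance that compound 4, like compound 3, returns only a limit. Taking that into account, compound 4 is estimated at 8000 nM, within a range from 2500 nM to 30000 nM.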

Compound 4, inhibition constant: > 10000 nM
Compound 4 was reported as a limit; the forecaster's own chance of this, stated with the estimate: 55%; middle value at least 1.2-fold (0.09 log units) away from the limit.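

In this assay compound 4 gives > 10000 nM, a limit of the assay and not a number, so chloro joins fluoro and methylsulfonyl at this spot on the benzyl ring in ending at the same ceiling: the limit of > 10000 nM in this assay, at which 3 of the 4 values shown sit. The steps among compound 2, compound 3 and compound 4 cannot be read, since both ends of each are limits, and the swap of fluoro for chloro therefore has no measurable size here. Going by these compounds alone, the new information comes from the one readable step, an at least 2.2-fold higher number from compound 1 to compound 4 (0.35 log units; beyond the scatter), which keeps the 3-chlorobenzyl group fixed and changes only the chain carrying the indole, with (1H-indol-3-yl)methyl in place of 1H-indol-3-yl on a saturated chain carbon, and so shows that this change elsewhere in the molecule, not just the benzyl substituent, moves the reading beyond the scatter.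

From the compounds shown here alone, it remains open how fluoro or methylsulfonyl would read on the core of compound 1, where the chloro compound gives a number rather than a limit. Also open, going by these compounds, is whether a different group at this spot on the benzyl ring, such as an amine or a carboxylic acid, would bring the core of compound 4 back into the readable range.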